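Expected Toxicity of Compound 3 After One Fluoro Is Removed

A few compounds are considered here, and "the series" means these few. Any claim that something is new, unique, unknown or untested is made for them only; others in the source may bear on it.

Of the compounds shown here, two have been measured in a toxicity assay on the whole organism (strain CD-1) for cytotoxicity, with Mus musculus as the target, with a stated time of 14 days, at a dose of 300 mg/kg by the intraperitoneal route; a higher number here means a weaker effect of the compound at the dose given, a lower number a stronger effect. Compound 1, `O=C(O)c1cc(F)c(F)c(F)c1O`, gives 0% in this assay. Compound 2, `COC(=O)c1c(O)c(F)c(F)c(F)c1F`, gives 0% in this assay. Compound 2 stands level with compound 1 at the digits reported; its nearest measured neighbour is compound 1, and the two show no change at the digits reported, which lies within the scatter.

Compound 3, `COC(=O)c1cc(F)c(F)c(F)c1O`, has not yet been measured in this assay. It differs from compound 2 in one place: hydrogen in place of fluoro on an aromatic carbon. A fluoro leaves and a hydrogen enters on an aromatic carbon of the ring shared by both compounds. Within the data shown here, no step between measured compounds is available in this assay, so the size of the change that such a replacement brings cannot be read from the data. Because compound 1 gives 0% and compound 2 gives 0%, the author expects no step beyond the scatter. The step from compound 2 to compound 3 is expected to be no change at the digits printed from compound 2 to compound 3 (within the scatter). Compound 3 is estimated to give 0% in this assay, within a range from 0% to 10%.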

Compound 3, a percentage reported as activity, at one dose (the size of the read-out at that dose, not a potency): 0%
Compound 3: middle estimate and measured number agree at the digits printed; measured number inside the range.
By their numbers in this assay, from the lowest: compounds 1, 2 and 3 (each within the scatter of the next).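

Among these compounds, compound 3 gives the first measured step for hydrogen in place of fluoro on an aromatic carbon ortho to a methoxycarbonyl group: in this assay the reading shows no change at the digits printed from compound 2 to compound 3 (within the scatter) at this position. It also isolates a second single change, methyl in place of hydrogen on the oxygen of the acid, and that change shows no change at the digits printed from compound 1 to compound 3 (within the scatter) in the same assay, whereas compound 1 and compound 2 differ in more than one place and could not separate the two changes. The data therefore place each change alone at the same reading, although no measurement offered here accounts for that sameness and this reading is taken at one dose only.

Still open, as far as these compounds go, is whether anything other than these small changes would move the reading in this assay away from the level shared by all three compounds, for instance an amide or an amine in place of the methoxycarbonyl group, or a longer chain on its oxygen. Also open, from the compounds shown here alone, is whether removing a further fluoro, or replacing the hydroxy group with a methoxy group, would leave the reading where it stands.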